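The source may report more compounds than this note shows. Statements on the series, on what has been measured and on what is new or still open speak of the compounds shown alone.

Measured in a functional assay on MCF7 cells (Homo sapiens) for antiproliferative activity, read by sulforhodamine B assay, with a stated time of 48 h; a lower number here means a stronger inhibitor, a higher number a weaker inhibitor:
- compound 1 `O=C(NCCCNc1cc(-c2cn(-c3ccccc3)nc2-c2cccc(O)c2)ccn1)Nc1ccc(F)cc1`: 2320 nM
- compound 2 `O=C(NCCCNc1cc(-c2cn(-c3ccccc3)nc2-c2cccc(O)c2)ccn1)Nc1cccc(C(F)(F)F)c1`: 2730 nM

Among the measured compounds shown here, compound 1 has only one measured neighbour, and the two values lie within the scatter of each other: a 1.2-fold higher number from compound 1 to compound 2 (0.07 log units; within the scatter). Neither compound therefore stands out in this assay.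

The next compound is compound 3 `COc1cccc(-c2nn(-c3ccccc3)cc2-c2ccnc(NCCCNC(=O)Nc3ccc(F)cc3)c2)c1`, which keeps the core and the 4-fluorophenyl of compound 1. The change is methyl in place of hydrogen on an oxygen on an aromatic ring, taking 3-hydroxyphenyl to 3-methoxyphenyl.

Evidence for this change is thin. For the measured compounds named here, the one measured step, a 1.2-fold higher number from compound 1 to compound 2 (0.07 log units; within the scatter), is a change on an amide-type nitrogen and does not touch the oxygen. It shows only that one substitution in this series left the number within the scatter. Going by the values given here, no measured pair shows what happens when the hydroxy group is replaced, so the direction remains open, and the range must stay wide.

A step no larger than the scatter is expected in this assay, with a slight drift to a higher number as a weak guess. The expected step is a 1.2-fold higher number from compound 1 to compound 3 (0.08 log units; within the scatter). For compound 3 the estimated value is 2800 nM, with an expected range of 1100 nM to 7000 nM.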

Compound 3, half-maximal inhibitory concentration: 7170 nM
Compound 3: middle estimate off by 2.6-fold (0.41 log units), on the low side; the measured number lies above the stated range.
By their numbers in this assay, from the lowest: compounds 1 and 2 (each within the scatter of the next); then compound 3.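

Replacing hydrogen with methyl on the oxygen, taking hydroxy to methoxy, gives the series its first step beyond the scatter in this assay: a 3.1-fold higher number from compound 1 to compound 3 (0.49 log units; beyond the scatter). Among the compounds shown here, the only earlier step, a 1.2-fold higher number from compound 1 to compound 2 (0.07 log units; within the scatter), lay on an amide-type nitrogen and stayed within the scatter, so this pair is the first sign that the number responds to a change on the aromatic oxygen, with the free hydroxy on the lower side. No measurement available here bears on what lies behind this rise.

This is a single pair, with the 4-fluorophenyl held constant, so the shown compounds leave open whether the same methyl gives a step of similar size alongside the 3-(trifluoromethyl)phenyl of compound 2. They also leave open whether the rise follows from the methyl itself or from the loss of the hydrogen on that oxygen, and how the number would respond to an ethoxy group, an amine or a carboxylic acid in place of the hydroxy.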